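Compound 3: iodo in place of furan-2-yl

The source may hold more compounds than are shown below. What is called first, only, known or untested is meant among the compounds shown, and "the series" means these compounds.

For the measured compounds named here, in a functional assay on K562 cells (Homo sapiens), read by MTT assay, with a stated time of 72 h (on this read-out higher numbers stand for weaker inhibition and lower numbers for stronger inhibition), compound 1 (`CNc1ncnc2c1c(-c1ccco1)cn2[C@@H]1O[C@H](CO)[C@@H](O)[C@H]1O`) gives 220 nM as the only numeric value so far. Compound 2 (`Nc1nc2c(c(-c3cccs3)cn2[C@@H]2O[C@H](CO)[C@@H](O)[C@H]2O)c(=O)[nH]1`) reads > 20000 nM in this assay and that entry is a limit of the assay, not a number. Going by the values given here, compound 1 is therefore the single measured anchor, and no pair of measured compounds isolates one change.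

Compound 3 (`CNc1ncnc2c1c(I)cn2[C@@H]1O[C@H](CO)[C@@H](O)[C@H]1O`) keeps the core of compound 1 and carries iodo in place of furan-2-yl on an aromatic carbon. Among the compounds with values here, with no measured step to lean on in this assay the expectation is loose: a moderate move toward weaker inhibition, beyond the usual scatter. The estimated change is a 4.5-fold higher number from compound 1 to compound 3 (0.66 log units; beyond the scatter) on that reading. For compound 3 the expected value is 1000 nM with an estimated range of 120 nM to 8000 nM for now.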

Compound 3, half-maximal inhibitory concentration: > 100000 nM
Compound 3 was reported as a limit; the forecaster's own chance of this, stated with the estimate: 7%; at least 100-fold (2.00 log units) between middle value and limit.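

For the compounds shown here, replacing furan-2-yl with iodo on this aromatic carbon gives an at least 450-fold higher number from compound 1 to compound 3 (2.65 log units; beyond the scatter), the first step that isolates a single change. In this assay, the result shows that, on the core of compound 1, one iodine atom does not preserve the inhibition seen with the five-membered aromatic ring of furan-2-yl. Compound 3 sits at a limit of the assay, not at a number, so the step gives only a bound: the limit of > 100000 nM in this assay, at which 1 of the 3 values shown sits.

The compounds shown leave open whether the loss reflects the absence of a ring at this position or something particular to iodo. A phenyl ring or a bare hydrogen at the same carbon on the core of compound 1 would separate those two readings.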